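Chloro in place of hydrogen on the phenyl of compound 3

The compounds below may be only part of what the source reports. "The series", "measured", "known", "first", "only" and "open" are said of these compounds alone.

Of the compounds shown here, three sharing one core have been tested in a functional assay on HeLa cells (Homo sapiens) for antiproliferative activity, read by MTT assay, with a stated time of 72 h; on this read-out lower numbers stand for stronger inhibition and higher numbers for weaker inhibition. Compound 1 `COc1ccccc1-c1ncnn1-c1cc(OC)c(OC)c(OC)c1` gives only a limit in this assay, > 10000 nM. Compound 3 `COc1cc(-n2ncnc2-c2ccccc2)cc(OC)c1OC` likewise gives only a limit, > 10000 nM. Compound 2 `COc1ccc(-c2ncnn2-c2cc(OC)c(OC)c(OC)c2)cc1`, by contrast, gives a number in this assay, 280 nM. Compound 3 thus stands at the limit that the limit of > 10000 nM in this assay, at which 2 of the 3 values shown sit, marks, together with compound 1, while compound 2 stands apart from both. The change from compound 3 to compound 2 is the return of methoxy on an aromatic carbon, and it is read as an at least 35-fold higher number from compound 2 to compound 3 (1.55 log units; beyond the scatter) in the opposite direction; the move from 2-methoxyphenyl to 4-methoxyphenyl is read as an at least 35-fold lower number from compound 1 to compound 2 (1.55 log units; beyond the scatter).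

Compound 4 `COc1cc(-n2ncnc2-c2ccc(Cl)cc2)cc(OC)c1OC` differs from compound 3 by chloro in place of hydrogen on an aromatic carbon. The same position that carries the methoxy in compound 2 here carries chloro, so the step from compound 2 to compound 3 is the one that bears on it, and it was large. Compound 4 is therefore expected to move away from the limit, an estimated step of an at least 8.3-fold lower number from compound 3 to compound 4 (0.92 log units; beyond the scatter) in this assay. The estimate for compound 4 is 1200 nM, in a range from 250 nM to 10000 nM.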

Compound 4, half-maximal inhibitory concentration: > 10000 nM
Compound 4: a limit, no number (the forecaster's own chance of this, stated with the estimate: 30%); at least 8.3-fold (0.92 log units) between middle value and limit.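

In this assay, the step with chloro in place of methoxy is an at least 35-fold higher number from compound 2 to compound 4 (1.55 log units; beyond the scatter), so filling the place para to a large group is not enough on its own: of the three cases shown there, only the methoxy of compound 2 gives a number, while hydrogen and chloro do not. Compound 4 gives > 10000 nM, which is a limit of the assay and not a number. The steps that link compound 4 to compound 3 and to compound 1 cannot be read, and the 4-chlorophenyl compound joins the others at the same limit: the limit of > 10000 nM in this assay, at which 3 of the 4 values shown sit.

Among these compounds, it remains open whether methoxy is the only group at this place that gives a number, or whether an ethoxy group, a methylthio group or an amine would also do so. On these data alone, how far compound 3 and compound 4 each lie past the limit also remains unknown, so it cannot be said whether chloro changes anything relative to hydrogen.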